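Ethyl for tert-butyl on the sulfonamide aryl ring

A few compounds are considered here, and "the series" means these few. Any claim that something is new, unique, unknown or untested is made for them only; others in the source may bear on it.

Of the compounds shown here, two have been measured so far in an assay on isolated protein for binding affinity to histamine H2 receptor (Homo sapiens); a lower number here means a stronger inhibitor, a higher number a weaker inhibitor. Compound 1 `COc1ccc(S(=O)(=O)N[C@H]2CCN(CCCOc3ccc(C(=O)C4CC4)cc3)C2)cc1` gives 1000 nM in this assay. Among the compounds with values here, compound 2 `CC(C)(C)c1ccc(S(=O)(=O)N[C@H]2CCN(CCCOc3ccc(C(=O)C4CC4)cc3)C2)cc1` gives 730 nM in this assay, which is the lowest of the two numbers; the only step known, a 1.4-fold lower number from compound 1 to compound 2 (0.14 log units; within the scatter), lies within the scatter. Compound 3 `CCc1ccc(S(=O)(=O)N[C@H]2CCN(CCCOc3ccc(C(=O)C4CC4)cc3)C2)cc1` has not yet been measured. It differs from compound 2 by ethyl in place of tert-butyl on an aromatic carbon. Within the data shown here, no measured step changes the same group in the same way, so the only guide is that swapping methoxy for tert-butyl at this position, a 1.4-fold lower number from compound 1 to compound 2 (0.14 log units; within the scatter), did not move the number beyond the scatter. On that basis the exchange for ethyl is expected to leave this assay roughly unchanged, with no step beyond the scatter. Compound 3 is therefore estimated at 800 nM in this assay, within the range 350 nM to 2000 nM, corresponding to an expected step of a 1.1-fold higher number from compound 2 to compound 3 (0.04 log units; within the scatter).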

Compound 3, inhibition constant: 330 nM
Compound 3: middle estimate off by 2.4-fold (0.38 log units), on the high side; measured number below the stated range.
By their numbers in this assay, from the lowest: compound 3; then compounds 2 and 1 (each within the scatter of the next).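

The aromatic position carrying these groups turns out to respond in this assay: the earlier exchange of methoxy for tert-butyl stayed within the scatter (a 1.4-fold lower number from compound 1 to compound 2 (0.14 log units; within the scatter)), whereas ethyl moves the number beyond it from both neighbours (a 2.2-fold lower number from compound 2 to compound 3 (0.34 log units; beyond the scatter); a 3.0-fold lower number from compound 1 to compound 3 (0.48 log units; beyond the scatter)). Compound 3 therefore stands apart from both compound 1 and compound 2, and at this position the ethyl group, with two carbons, gives a lower number than the four-carbon tert-butyl group. Nothing available explains why ethyl differs from the other two groups.

Within the data shown here, with only three groups compared, a single pair of alkyl groups cannot show whether the number follows chain length, and methyl, n-propyl or isopropyl at this position would be needed to test that. Going by these compounds, how a chlorine atom or an amine would behave there also remains open, as does whether the effect of ethyl holds when the cyclopropyl ketone is changed.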